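A few compounds are considered here, and "the series" means these few. Any claim that something is new, unique, unknown or untested is made for them only; others in the source may bear on it.

Working notes on the series. Compound 1 `O=C(N/N=C/C1=C(Cl)c2ccccc2CCC1)c1cccnc1` is the starting point; in a functional assay (MiaPaCa cells, Homo sapiens) for inhibition, read by sulforhodamine B assay, with a stated time of 48 h (a higher number here means a weaker inhibitor of growth, a lower number a stronger inhibitor of growth), compound 1 gives 11700 nM. Compound 2 `O=C(N/N=C/C1=C(Cl)c2ccccc2CCC1)c1cccc(I)c1` differs from compound 1 by 3-iodophenyl in place of pyridin-3-yl on a carbonyl carbon, and in this assay compound 2 gives 1600 nM. For the measured compounds named here, the only measured step in the set is a 7.3-fold lower number from compound 1 to compound 2 (0.86 log units; beyond the scatter). Compound 3 `Cc1cc2c(cc1C)C(Cl)=C(/C=N/NC(=O)c1cccnc1)CCC2` keeps the pyridin-3-yl group of compound 1 on a different core; the difference between the two cores is not broken down here. In this assay compound 3 gives 1600 nM, level with compound 2 within the scatter, and both stand lower than compound 1.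

Compound 4 `Cc1cc2c(cc1C)C(Cl)=C(/C=N/NC(=O)c1cccc(I)c1)CCC2` has not yet been measured. Going by the values given here, it differs from compound 3 by 3-iodophenyl in place of pyridin-3-yl on a carbonyl carbon, which is the same change, at the same place, as the one between compound 1 and compound 2. The expectation for compound 4 rests on one pair only: on the core of compound 1 the change produced a 7.3-fold lower number from compound 1 to compound 2 (0.86 log units; beyond the scatter), so a step in the same direction is expected on the core of compound 3 as well. Whether the lowering seen from compound 1 to compound 2 carries over in full to a core that already stands at the level of compound 2 cannot be read from three measured compounds, so the expected step from compound 3 to compound 4 is taken as a 3.6-fold lower number from compound 3 to compound 4 (0.55 log units; beyond the scatter), somewhat smaller than the earlier one. Compound 4 is therefore expected to give 450 nM in this assay, within an estimated range from 150 nM to 1600 nM.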

Compound 4, concentration for 50% growth inhibition: 4300 nM
For compound 4 the middle estimate is 9.6-fold (0.98 log units) below the measured one; the whole stated range lies below it.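

In this assay the change of pyridin-3-yl to 3-iodophenyl on a carbonyl carbon does not carry over from the core of compound 1 to the other core, where it gives a 2.7-fold higher number from compound 3 to compound 4 (0.43 log units; beyond the scatter), a step opposite in direction to the earlier one. Within these four compounds, the result of this change therefore depends on the core that carries it, and the two steps cannot be treated as one shared effect: the same change on two cores in this assay, a 7.3-fold lower number (0.86 log units; beyond the scatter) from compound 1 to compound 2 and a 2.7-fold higher number (0.43 log units; beyond the scatter) from compound 3 to compound 4, 20-fold (1.29 log units) apart, beyond the scatter of two such steps This does not show which part of the difference between the cores matters or why the direction reverses, and with a single pair on each core it gives no general preference for either group and no rule for predicting the change on a third core.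

The compounds shown leave open whether a plain phenyl group, or a phenyl group carrying an amine or a carboxylic acid, on the same carbonyl carbon would follow the pattern of the core of compound 1 or that of the core of compound 3 in this assay. They also leave open whether the reversal extends to a core that differs from these two in only part of its structure.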